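Aryl amide variation on a trifluoromethyl diol chain

This account rests on a few compounds, and the source may have more. Where it says the series, first, only, none or still open, it means among the compounds named here.

Measured so far in a functional assay on HCT-116 cells (Homo sapiens) for inhibition, read by colorimetric assay, with a stated time of 3 days; a lower number here means a stronger inhibitor, a higher number a weaker inhibitor:
compound 1 `COc1ccc(-c2cnc(NC(=O)CCCCCCNC(=O)C(O)(O)C(F)(F)F)s2)cc1`: 930 nM
compound 2 `O=C(CCCCCCNC(=O)C(O)(O)C(F)(F)F)Nc1ccccc1Br`: 14500 nM
compound 3 `NC(=O)C(=O)NCCCCCCCC(=O)Nc1ccccc1`: > 100000 nM (a limit, not a number)

Compound 2 holds the highest of the two numbers; compound 1 sits lower, and the gap between them is well beyond the scatter. For compound 3 the assay gives only (the limit of > 100000 nM in this assay, at which 1 of the 3 values shown sits), so no number is known for it. For the measured compounds named here, no pair of measured compounds differs in one place, so no measured step is available for the change that follows.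

Compound 4 `CC(=O)c1ccc(NC(=O)CCCCCCNC(=O)C(O)(O)C(F)(F)F)cc1` is not yet measured. It differs from compound 2 at a single point: 4-acetylphenyl in place of 2-bromophenyl on an amide-type nitrogen. Compound 1, with a larger aromatic group on the same amide nitrogen and the same chain, gives 930 nM, which leaves room for a substituted aryl at this position to score lower than compound 2. The step from compound 2 to compound 4 is expected to be a moderate lowering, a 2.4-fold lower number from compound 2 to compound 4 (0.38 log units; beyond the scatter), likely just beyond the scatter. Compound 4 is estimated at 6000 nM. For compound 4 the expected range runs from 1500 nM to 25000 nM.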

Compound 4, half-maximal inhibitory concentration: 12100 nM
For compound 4 the middle estimate is 2.0-fold (0.30 log units) below the measured one, within the range that was stated.
By their numbers in this assay, from the lowest: compound 1; then compounds 4 and 2 (each within the scatter of the next). At a limit, above all of these: compound 3.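

Working notes: the step of a 1.2-fold lower number from compound 2 to compound 4 (0.08 log units; within the scatter) shows that in this assay this position does not separate these two substituted phenyl groups, although the entering 4-acetylphenyl carries a hydrogen-bond acceptor and the leaving 2-bromophenyl does not. Both the substituent and its place on the ring change in this one step, so neither can be read alone, and among the aryl amides with a number, the value of 930 nM for compound 1 remains clearly the lowest beside the two phenyl amides. No measured evidence gives a cause for this result.

From the compounds shown here alone, whether a 4-bromophenyl or 2-acetylphenyl group would match compound 4 stays open, which would separate substituent from ring place. Also open, going by these compounds, is how a 4-aminophenyl group, a 4-carboxyphenyl group or a longer chain would read on the same scaffold.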